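The compounds below may be only part of what the source reports. "The series", "measured", "known", "first", "only" and "open" are said of these compounds alone.

Of the compounds shown here, three of one family have been tested in a functional assay on Jurkat cells (Homo sapiens) for cytotoxicity, read by MTT assay, with a stated time of 48 h; on this read-out lower numbers stand for stronger inhibition and higher numbers for weaker inhibition. Compound 1, whose structure is `O=C(Nc1cc(C(F)(F)F)ccc1N1CCCC1)c1cccnc1Cl`, carries a pyrrolidin-1-yl group on its core. In this assay compound 1 is recorded as "not active" (no number reported), an outcome without a number rather than a measured concentration. Compound 3, `O=C(Nc1cc(C(F)(F)F)ccc1N1CCCC1)c1ccccc1`, shares that pyrrolidin-1-yl group, and in this assay compound 3 is likewise recorded as "not active" (no number reported). Within the data shown here, compound 2, `O=C(Nc1cc(C(F)(F)F)ccc1NC1CCCCC1)c1ccncc1`, is the only one with a number: in this assay compound 2 gives 80900 nM, a weak effect. So compound 1 stands among the compounds for which no concentration could be given.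

Compound 4, `CCN(CC)c1ccc(C(F)(F)F)cc1NC(=O)c1cccnc1Cl`, differs from compound 1 in one place: diethylamino in place of pyrrolidin-1-yl on an aromatic carbon. Among the measured compounds shown here, no measured pair shows what this exchange does here. With its two nearest relatives giving no number and the third a weak value, compound 4 is expected to stay in that weak region, most likely again without a number. The estimated value for compound 4 in this assay is 100000 nM, within a range from 30000 nM to 300000 nM.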

Compound 4, half-maximal inhibitory concentration: 88400 nM
The estimate for compound 4 lay 1.1-fold (0.05 log units) above the measured number; measured number inside the range.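

Among these compounds, compound 1 has no number in this assay while compound 4 has one, and no step between them can be read. The compounds shown leave open what diethylamino in place of pyrrolidin-1-yl does to cytotoxicity. No measurement shown here offers an explanation for the result of compound 4.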